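A few compounds are considered here, and "the series" means these few. Any claim that something is new, unique, unknown or untested is made for them only; others in the source may bear on it.

Measured in a functional assay on CCRF-CEM cells (Homo sapiens) for cytotoxicity, read by XTT assay, with a stated time of 3 days; on this read-out higher numbers stand for weaker inhibition and lower numbers for stronger inhibition:
- compound 1 `OC[C@H]1O[C@@H](n2cc(F)c3c(-c4ccccc4)ncnc32)[C@H](O)[C@@H]1O` gives 3100 nM
- compound 2 `OC[C@H]1O[C@@H](n2cc(F)c3c(-c4ccco4)ncnc32)[C@H](O)[C@@H]1O` gives 1400 nM
- compound 3 `OC[C@H]1O[C@@H](n2cc(Cl)c3c(-c4ccccc4)ncnc32)[C@H](O)[C@@H]1O` gives 910 nM

Compound 3 stands within the scatter of compound 2 and well under compound 1, with a 3.4-fold lower number from compound 1 to compound 3 (0.53 log units; beyond the scatter) for chloro in place of fluoro. The next change leads to compound 4 `OC[C@H]1O[C@@H](n2cc(Cl)c3c(-c4ccco4)ncnc32)[C@H](O)[C@@H]1O` and is furan-2-yl in place of phenyl on an aromatic carbon. Within the data shown here, the same exchange with fluoro present gave a 2.2-fold lower number from compound 1 to compound 2 (0.35 log units; beyond the scatter), a modest step and the only direct precedent. A similar modest move to a lower number is therefore expected in this assay, although a single pair is thin support. The expected change is a 2.1-fold lower number from compound 3 to compound 4 (0.33 log units; beyond the scatter). For compound 4 the estimated value is 430 nM, with an expected range from 190 nM to 950 nM.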

Compound 4, half-maximal inhibitory concentration: 3800 nM
Estimate against measurement, compound 4: 8.8-fold (0.95 log units) below; the measured number lies above the stated range.
By their numbers in this assay, from the lowest: compounds 3 and 2 (each within the scatter of the next); then compounds 1 and 4 (each within the scatter of the next).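

With chloro on the core, furan-2-yl in place of phenyl gives a 4.2-fold higher number from compound 3 to compound 4 (0.62 log units; beyond the scatter) and so has no fixed direction at this position: the same change on two cores in this assay, a 2.2-fold lower number (0.35 log units; beyond the scatter) from compound 1 to compound 2 and a 4.2-fold higher number (0.62 log units; beyond the scatter) from compound 3 to compound 4, 9.2-fold (0.97 log units) apart, beyond the scatter of two such steps.
Chloro in place of fluoro likewise reverses with furan-2-yl present, giving a 2.7-fold higher number from compound 2 to compound 4 (0.43 log units; beyond the scatter) and not a lower number: the same change on two cores in this assay, a 3.4-fold lower number (0.53 log units; beyond the scatter) from compound 1 to compound 3 and a 2.7-fold higher number (0.43 log units; beyond the scatter) from compound 2 to compound 4, 9.2-fold (0.97 log units) apart, beyond the scatter of two such steps.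
The halogen and the aromatic group therefore cannot be read as independent changes across compounds 1 to 4.

Open: whether an amine or a methyl group at this position would follow phenyl or furan-2-yl, and whether bromo on the core would follow chloro or fluoro. What lies behind the reversal cannot be told from these four compounds.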